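The source may hold more compounds than are shown below. What is called first, only, known or untested is meant among the compounds shown, and "the series" means these compounds.

The study concerns three compounds sharing one core. Compound 1 `CCCc1nnc(SCC(=O)c2ccccc2)n1N1C(=O)c2ccccc2C1=O` carries a benzoyl group on its sulfur-linked arm and a small substituent on the core. In a functional assay on MKN-45 cells (Homo sapiens) for cytotoxicity, read by MTT assay, with a stated time of 48 h (a higher number here means a weaker inhibitor, a lower number a stronger inhibitor), compound 1 gives only a limit of the assay, > 200000 nM. Compound 2 `COc1cc(-c2nnc(SCC(=O)c3ccc(Cl)cc3)n2N2C(=O)c3ccccc3C2=O)cc(OC)c1OC` carries a (4-chlorophenyl)carbonyl group and a larger substituent on the core. In this assay compound 2 gives 26600 nM, the only number shown. The other value is a limit, as the limit of > 200000 nM in this assay, at which 1 of the 2 values shown sits, records. Compound 3 `COc1cc(-c2nnc(SCC(=O)c3ccccc3)n2N2C(=O)c3ccccc3C2=O)cc(OC)c1OC` is compound 2 with one change: hydrogen in place of chloro on an aromatic carbon. For the measured compounds named here, no step between measured compounds is available; compound 1 and compound 3 share the benzoyl group but differ on the core as well, so their values can only be set side by side. The step of a 1.9-fold higher number from compound 2 to compound 3 (0.27 log units; within the scatter) is expected to go toward a weaker inhibitor, by a modest amount that may not clear the usual scatter. Compound 3 is therefore estimated at 50000 nM, within a range from 15000 nM to 200000 nM, with a fair chance that this assay again reports only a limit.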

Compound 3, half-maximal inhibitory concentration: > 200000 nM
Compound 3: only a limit was reported; the forecaster's own chance of this, stated with the estimate: 25%; middle value at least 4.0-fold (0.60 log units) from the limit.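

In this assay, hydrogen in place of chloro, on an aromatic carbon para to a large group, gives an at least 7.5-fold higher number from compound 2 to compound 3 (0.87 log units; beyond the scatter), beyond the scatter. For the compounds shown here, this is the first change in one place that can be read, and it shows that the 3,4,5-trimethoxyphenyl group on the core does not by itself keep a measurable value: with benzoyl in place of (4-chlorophenyl)carbonyl, the number is lost to a limit of the assay. The step between compound 1 and compound 3 cannot be read, and the series now rests mostly on limits: the limit of > 200000 nM in this assay, at which 2 of the 3 values shown sit.

What the compounds shown leave open is whether chloro itself is needed, or whether another group on that aromatic carbon, such as bromo, methoxy or an amine, would give a measurable value as well. They also leave open whether chloro would have any such effect with propyl on the core, as in compound 1, and how far the true value of compound 3 lies beyond its limit.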